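The source may hold more compounds than are shown below. What is called first, only, known or untested is meant among the compounds shown, and "the series" means these compounds.

Three compounds from the series have been measured in a functional assay on SK-BR-3 cells (Homo sapiens) for antiproliferative activity; on this read-out higher numbers stand for weaker inhibition and lower numbers for stronger inhibition:

compound 1 `COc1ccc(Oc2ccc3cc(NC(=O)c4ccc(OC(C)=O)c(CC=C(C)C)c4)c(=O)oc3c2C)cc1`: 19500 nM
compound 2 `CC(C)=CCc1cc(C(=O)Nc2cc3ccc(Oc4ccc(C(C)(C)C)cc4)c(C)c3oc2=O)ccc1O`: 68300 nM
compound 3 `COc1ccc(Oc2ccc3cc(NC(=O)c4ccc(OC)c(-c5cccc(OC)c5)c4)c(=O)oc3c2C)cc1`: > 100000 nM

Compound 1 and compound 2 each give a number in this assay, and both numbers lie high on the scale; of the two, compound 2 gives the weaker inhibition. For compound 3 the picture is different. In this assay compound 3 gives only > 100000 nM, which is a limit of the assay and not a number. This is the limit of > 100000 nM in this assay, at which 1 of the 3 values shown sits. Among the compounds with values here, compound 3 therefore stands at the weak end of what has been seen so far, and no step to either of the other two compounds can be sized from it.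

Compound 4 `COc1cccc(Oc2ccc3cc(NC(=O)c4ccc(OC)c(-c5cccc(OC)c5)c4)c(=O)oc3c2C)c1` has not been measured. It differs from compound 3 in one place: 3-methoxyphenyl in place of 4-methoxyphenyl on an oxygen on an aromatic ring. The same atoms are present in both; they are joined differently. Within the data shown here, with compound 3 already at the limit, there is no measured step that bears on this kind of rearrangement, and no movement beyond the usual scatter is expected. The estimated step of a number no higher from compound 3 to compound 4 (the limit leaves the size open) is none beyond the scatter. Compound 4 is expected to come out near 100000 nM, with a range from 30000 nM to 300000 nM.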

Compound 4, half-maximal inhibitory concentration: > 100000 nM
Compound 4 ended at the assay's limit; the forecaster's own chance of this, stated with the estimate: 70%; the middle value sits exactly at the limit.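

In this assay compound 4 gives > 100000 nM, which is a limit of the assay and not a number. Compound 3 also stands at a limit, so no step between compound 3 and compound 4 can be read: the limit of > 100000 nM in this assay, at which 2 of the 4 values shown sit.

The compounds shown leave open what 3-methoxyphenyl in place of 4-methoxyphenyl does to inhibition.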